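A few compounds are considered here, and "the series" means these few. Any claim that something is new, unique, unknown or untested is made for them only; others in the source may bear on it.

Measured compounds:
compound 1 `O=C(CCCCC1CCCCC1)OCC1COCCOCCOCCOCCOCCO1`: 71000 nM in a functional assay on HeLa cells (Homo sapiens) for inhibition, read by sulforhodamine B assay, with a stated time of 48 h; on this read-out lower numbers stand for stronger inhibition of growth and higher numbers for weaker inhibition of growth
compound 2 `CC(=O)OCC1COCCOCCOCCOCCOCCO1`: > 100000 nM in this assay

For compound 2 the assay reports only a limit, (the limit of > 100000 nM in this assay, at which 1 of the 2 values shown sits), and no number. Within the data shown here, the single measured step, an at least 1.4-fold higher number from compound 1 to compound 2 (0.14 log units; that floor lies within the scatter), removes a 3-cyclohexylpropyl chain and reaches that limit. Compound 3 `O=C(CCCCc1ccccc1)OCC1COCCOCCOCCOCCOCCO1` reverses a change of the same kind: 3-phenylpropyl in place of hydrogen on a saturated chain carbon bound to a carbonyl carbon. On this basis compound 3 is expected to return to the range of compound 1, with an estimated 80000 nM (range 30000 nM to 200000 nM), which would mean an expected step of an at least 1.2-fold lower number from compound 2 to compound 3 (0.09 log units; that floor lies within the scatter) from the limit of compound 2.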

Compound 3, concentration for 50% growth inhibition: 52000 nM
Compound 3: the middle estimate sits 1.5-fold (0.19 log units) above what was measured; low and high end bracket the measured number.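

In this assay, a six-membered ring of carbon at the end of the chain can be aromatic or saturated without a difference that can be read, with a 1.4-fold lower number from compound 1 to compound 3 (0.14 log units; within the scatter). The second ring-bearing chain, 3-phenylpropyl in place of hydrogen, gives an at least 1.9-fold lower number from compound 2 to compound 3 (0.28 log units; that floor lies within the scatter), so the size of this change at this position remains unresolved. Compound 2 gives only a limit, not a number: the limit of > 100000 nM in this assay, at which 1 of the 3 values shown sits.

Whether the ring or the chain alone accounts for the measurable values stays open. So does the effect of a longer chain, or of an amine or a carboxylic acid at the chain end.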